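The source may report more compounds than this note shows. Statements on the series, on what has been measured and on what is new or still open speak of the compounds shown alone.

Measured so far:
- compound 1, `COc1ccc(C)c(N2CCC(COc3cccc(C(CC(=O)O)C4CC4)c3)CC2)c1`: 113%
- compound 2, `COc1ccc(C(C)C)c(N2CCC(COc3cccc(C(CC(=O)O)C4CC4)c3)CC2)c1`: 117%

In a functional assay on cells for agonist activity at Free fatty acid receptor 1 (Homo sapiens), read by FLIPR and calcium flux, with a stated time of 60 min (on this read-out higher numbers stand for larger maximal responses and lower numbers for smaller maximal responses), compound 1 gives 113%, and compound 2 gives 117%. For the measured compounds named here, the only step between them is a number 4 percentage points higher from compound 1 to compound 2 (within the scatter), so the two values sit within the scatter of each other and neither can be called the larger response.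

Compound 3, `COc1ccc(CCC(C)(C)C)c(N2CCC(COc3cccc(C(CC(=O)O)C4CC4)c3)CC2)c1`, has not yet been measured. It carries the change (3,3-dimethylbutyl in place of isopropyl on an aromatic carbon). Going by the values given here, the one step that bears on this is the earlier growth of the group at the same place, a number 4 percentage points higher from compound 1 to compound 2 (within the scatter), which changed nothing beyond the scatter. Making that group longer again is therefore expected to leave the maximal response in this assay about where compound 2 stands, with no step beyond the scatter.

Compound 3 is expected to give 115%, within a range of 100% to 130%. The step this estimate implies is a number 2 percentage points lower from compound 2 to compound 3 (within the scatter), which is expected to fall inside the usual scatter.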

Compound 3, largest response reached (Emax), in percent of the reference or control that the assay uses: 110%
Beside the measured number, compound 3's estimate is 5 percentage points above it; measured number inside the range.
By their numbers in this assay, from the lowest: compounds 3, 1 and 2 (each within the scatter of the next).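

Swapping isopropyl for 3,3-dimethylbutyl, on the aromatic carbon para to a methoxy group, gives a number 7 percentage points lower from compound 2 to compound 3 (within the scatter) in this assay. Set against the methyl group of compound 1, the same chain gives a number 3 percentage points lower from compound 1 to compound 3 (within the scatter), so at this position a chain of 6 heavy atoms keeps the maximal response within the scatter of both smaller groups. Nothing available explains why these three carbon groups read alike.

Going by these compounds, all three groups contain only carbon, so the effect of an amine, a hydroxyl group or a carboxylic acid at this position remains open. A maximal response also does not show how much of each compound is needed to reach it, so these values leave any comparison of that kind unsettled.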